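The source may hold more compounds than are shown below. What is called first, only, known or untested is meant among the compounds shown, and "the series" means these compounds.

In a functional assay on SW480 cells (Homo sapiens) for antiproliferative activity, read by MTT assay, with a stated time of 48 h (on this read-out higher numbers stand for weaker inhibition and lower numbers for stronger inhibition), compound 2 `CCCCCCCCCCCC(CCO)n1cnc2c(NC)ncnc21` gives 12800 nM and compound 1 `CCCCCCCCCCCC(CCO)n1cnc2c(OC)ncnc21` gives 9700 nM, so the two cannot be separated within the scatter. Compound 3 `CCCCCCCCCCCC(CCO)n1cnc2c(N(C)C)ncnc21` differs from compound 2 by one change: methyl in place of hydrogen on a nitrogen on an aromatic ring. This is methyl in place of hydrogen on a nitrogen on an aromatic ring, or methylamino to dimethylamino. Among the compounds with values here, only one measured step bears on it, a 1.3-fold higher number from compound 1 to compound 2 (0.12 log units; within the scatter), where methylamino replaces methoxy on an aromatic carbon. Within the data shown here, that step involves the same group but stays within the scatter, and no measured pair shows what methyl in place of hydrogen does on this nitrogen. No shift beyond the scatter is therefore expected in this assay, and no direction can be favoured. The estimated change is a 1.0-fold higher number from compound 2 to compound 3 (0.01 log units; within the scatter). Compound 3 is expected at 13000 nM, with an estimated range of 6500 nM to 26000 nM.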

Compound 3, half-maximal inhibitory concentration: 11800 nM
The estimate for compound 3 lay 1.1-fold (0.04 log units) above the measured number; the measured number falls inside the stated range.
By their numbers in this assay, from the lowest: compounds 1, 3 and 2 (each within the scatter of the next).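

In this assay, within the data shown here, the first measured pair on this nitrogen shows a 1.1-fold lower number from compound 2 to compound 3 (0.04 log units; within the scatter), so methyl in place of hydrogen on a nitrogen on an aromatic ring brings no shift beyond the scatter. The comparison with the oxygen-linked group, a 1.2-fold higher number from compound 1 to compound 3 (0.09 log units; within the scatter), likewise stays within the scatter. Methoxy, methylamino and dimethylamino therefore cannot be separated at this place in this series, whether the attached atom is oxygen or nitrogen and whether the nitrogen carries a hydrogen or a methyl.

Still open, as far as these compounds go, is whether an unsubstituted amino group, a larger group such as morpholine or a longer chain such as ethyl on this nitrogen would move the number. Changes elsewhere on the shared core also remain open, for example a carboxylic acid in place of the terminal alcohol or a shorter alkyl chain.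

No measured data explain why these values stay so close.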